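Swapping the nitro-bearing ring for a dimethoxy-bearing ring

The source may hold more compounds than are shown below. What is called first, only, known or untested is meant among the compounds shown, and "the series" means these compounds.

Measured compounds:
Compound 1 `COc1cc(C(=O)c2sc(-c3ccc(C(F)(F)F)cc3)cc2N)cc(OC)c1OC`: 540 nM
Compound 2 `COc1cc(C(=O)c2sc(-c3cc(OC)c(OC)c(OC)c3)cc2N)cc(OC)c1OC`: 3500 nM
Compound 3 `COc1cc(C(=O)c2sc(-c3cccc([N+](=O)[O-])c3)cc2N)cc(OC)c1OC`: 17 nM

In a functional assay on FM3A cells (Mus musculus) for antiproliferative activity (a lower number here means a stronger inhibitor, a higher number a weaker inhibitor), compound 3 gives the lowest number of the three, compound 1 standing a 32-fold lower number from compound 1 to compound 3 (1.50 log units; beyond the scatter) away, and compound 2 further still. Compound 4 `COc1ccc(-c2cc(N)c(C(=O)c3cc(OC)c(OC)c(OC)c3)s2)cc1OC` differs from compound 3 by 3,4-dimethoxyphenyl in place of 3-nitrophenyl on an aromatic carbon. Among the measured compounds shown here, the one measured step, a 32-fold lower number from compound 1 to compound 3 (1.50 log units; beyond the scatter), shows that the ring attached here matters greatly. Compound 2, whose attached ring also carries several methoxy groups, gives 3500 nM, far weaker than compound 3. Compound 4 is therefore expected to lose most of the strength of compound 3, with an estimated step of an 88-fold higher number from compound 3 to compound 4 (1.95 log units; beyond the scatter). For compound 4 the estimated value is 1500 nM, in the range 300 nM to 6000 nM.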

Compound 4, half-maximal inhibitory concentration: 72 nM
Estimate against measurement, compound 4: 21-fold (1.32 log units) above; measured number outside the range, below it.
By their numbers in this assay, from the lowest: compound 3; then compound 4; then compound 1; then compound 2.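

Methoxy groups on the attached ring are not uniformly costly: taking away a single methoxy group gives a 49-fold lower number from compound 2 to compound 4 (1.69 log units; beyond the scatter) in this assay. A ring without a nitro group can also perform well here, since the 3,4-dimethoxyphenyl ring gives a 7.5-fold lower number from compound 1 to compound 4 (0.88 log units; beyond the scatter) and costs only a 4.2-fold higher number from compound 3 to compound 4 (0.63 log units; beyond the scatter). No measured evidence explains these steps. Still open, on these data alone, is how an amine or a hydroxyl group on this ring would compare, and whether any replacement could match or better 3-nitrophenyl.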